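This account rests on a few compounds, and the source may have more. Where it says the series, first, only, none or still open, it means among the compounds named here.

Measured in a functional assay on HeLa cells (Homo sapiens) for antiproliferative activity, read by MTT assay, with a stated time of 72 h; on this read-out lower numbers stand for stronger inhibition and higher numbers for weaker inhibition:

compound 1 `O=C1O/C(=C\Cn2cnc3cc[nH]c3c2=O)C(OCc2ccccc2)=C1OCc1ccccc1` gives 27000 nM
compound 2 `O=C1NC(O)(CCn2cnc3ccn(CCC4(O)NC(=O)C(OCc5ccccc5)=C4OCc4ccccc4)c3c2=O)C(OCc2ccccc2)=C1OCc1ccccc1` gives 17000 nM; 18000 nM (2 entries)
compound 3 `COc1nc(OC)c2c(ccn2CCC2(O)NC(=O)C(OCc3ccccc3)=C2OCc2ccccc2)n1` gives 92000 nM

Among the two single numbers compound 1 stands lowest; compound 3 lies at the higher number, and the gap between compound 1 and compound 3 is beyond the usual scatter. Compound 2 is recorded more than once, and the two entries the several entries of compound 2 in this assay, 17000 nM; 18000 nM (2 entries) agree closely, which gives some confidence in the repeatability of this assay at this level of potency. Within the data shown here, no pair among the three measured compounds differs in one place only, so no measured step is available to anchor a prediction.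

Compound 4 `O=C1O/C(=C\Cn2cnc3ccnc(Cl)c32)C(OCc2ccccc2)=C1OCc1ccccc1` differs from compound 1 in one place: a group of 10 heavy atoms (6 carbon, 3 nitrogen, 1 chlorine; one five-membered aromatic ring with 2 hetero atoms, one six-membered aromatic ring with 1 hetero atom) in place of a group of 10 heavy atoms (6 carbon, 3 nitrogen, 1 oxygen; one five-membered aromatic ring with 1 hetero atom, one six-membered aromatic ring with 2 hetero atoms), on a saturated chain carbon bound to a double-bonded chain carbon. The change keeps the same count of heavy atoms and acceptors while removing the single donor and introducing a chlorine. Without a measured step of this kind, the expectation is a step of small size, likely within the scatter, with no confident direction; a slight move toward a lower number is taken as marginally more likely. The expected step from compound 1 to compound 4 is a 1.4-fold lower number from compound 1 to compound 4 (0.13 log units; within the scatter). Compound 4 is therefore estimated at 20000 nM, in the range 6000 nM to 60000 nM.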

Compound 4, half-maximal inhibitory concentration: > 100000 nM
Compound 4 gave a limit, no number (the forecaster's own chance of this, stated with the estimate: 10%); middle value at least 5.0-fold (0.69 log units) from the limit.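

In this assay compound 4 gives > 100000 nM, which is a limit of the assay and not a number. Among these compounds, the exchange on a saturated chain carbon bound to a double-bonded chain carbon provides the first measured step, an at least 3.7-fold higher number from compound 1 to compound 4 (0.56 log units; beyond the scatter), so this place does not accept every group of this size without a loss in the read-out. The leaving and entering groups both hold 10 heavy atoms and 3 hydrogen-bond acceptors, so these shared counts alone do not preserve the activity of compound 1; they differ in the hydrogen-bond donor, the chlorine in place of the oxygen and the arrangement of hetero atoms in the rings.

Which of these differences carries the step stays open, and its full size also stays open since only a bound is available: the limit of > 100000 nM in this assay, at which 1 of the 4 values shown sits. An amine in place of the chlorine of compound 4 would restore a hydrogen-bond donor on the same ring arrangement and would help separate the effect of the donor from that of the ring hetero atoms.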